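The source may report more compounds than this note shows. Statements on the series, on what has been measured and on what is new or still open speak of the compounds shown alone.

The measured compounds and their values:

Compound 1, `CC(C)(C)OC(=O)N1CCC(O[C@H]2CC[C@H](Oc3ccc(S(C)(=O)=O)cc3)CC2)CC1`: 94 nM
Compound 2, `CC(C)(C)OC(=O)N1CCC(O[C@H]2CC[C@H](Oc3ccc(S(C)(=O)=O)c(F)c3)CC2)CC1`: 167 nM
Compound 3, `CC(C)(C)OC(=O)N1CCC(O[C@H]2CC[C@H](Oc3ccc(S(C)(=O)=O)cn3)CC2)CC1`: 110 nM

All three were tested in a functional assay on isolated protein for agonist activity at Glucose-dependent insulinotropic receptor (Rattus norvegicus), read by HTRF and cAMP accumulation; on this read-out lower numbers stand for an effect already at smaller amounts and higher numbers for an effect only at larger amounts of compound. Compound 3 sits within the scatter of both neighbours: the change from compound 1 gave a 1.2-fold higher number from compound 1 to compound 3 (0.07 log units; within the scatter), and the values of compound 3 and compound 2 differ by less than the usual scatter, so no ordering among the three can be read from these numbers.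

Compound 4, `CC(C)(C)OC(=O)N1CCC(O[C@H]2CC[C@H](Oc3cnc(C#N)cn3)CC2)CC1`, has not yet been measured. It differs from compound 3 in one place: 5-cyanopyrazin-2-yl in place of 5-(methylsulfonyl)pyridin-2-yl on an oxygen on a saturated carbon

For the measured compounds named here, the only step that exchanges the aromatic ring on that oxygen is a 1.2-fold higher number from compound 1 to compound 3 (0.07 log units; within the scatter), which stayed within the scatter; the other step, a 1.8-fold higher number from compound 1 to compound 2 (0.25 log units; within the scatter), changed a single ring position and also stayed within the scatter. Neither step tests a nitrile in place of a methylsulfonyl group, so the expectation rests on the observation that both changes so far were small. The expected step is a 1.4-fold higher number from compound 3 to compound 4 (0.13 log units; within the scatter), no larger than the scatter. Compound 4 is therefore estimated at 150 nM, with a likely range from 50 nM to 450 nM.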

Compound 4, half-maximal effective concentration: 28.4 nM
Estimate against measurement, compound 4: 5.3-fold (0.72 log units) above, outside the stated range (below it).
By their numbers in this assay, from the lowest: compound 4; then compounds 1, 3 and 2 (each within the scatter of the next).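

In this assay, the aromatic group on this oxygen can shift the number beyond the scatter: replacing 5-(methylsulfonyl)pyridin-2-yl with 5-cyanopyrazin-2-yl gave (a 3.9-fold lower number from compound 3 to compound 4 (0.59 log units; beyond the scatter)), and replacing 4-(methylsulfonyl)phenyl with the same group gave (a 3.3-fold lower number from compound 1 to compound 4 (0.52 log units; beyond the scatter)). Compound 4 has no methylsulfonyl group, so that group is not required for activity at this receptor, and a nitrile on a pyrazine ring can take its place with a lower number. No measurement available here explains this shift.

The exchange altered the ring and its substituent together, so the shift cannot be assigned to either alone; 5-cyanopyridin-2-yl, with the nitrile on the ring of compound 3, would separate the two. Also open, on these data alone, is how a primary amide or a carboxylic acid in place of the nitrile would behave.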